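Hydrazone-amide series: moving a trifluoromethyl on the acyl ring

The source may report more compounds than this note shows. Statements on the series, on what has been measured and on what is new or still open speak of the compounds shown alone.

Measured compounds in a functional assay on A549 cells (Homo sapiens) for inhibition, read by MTT assay, with a stated time of 72 h; on this read-out lower numbers stand for stronger inhibition and higher numbers for weaker inhibition:
compound 1 `CN(C(=O)NC(=O)c1cccc(C(F)(F)F)c1)c1nc(C(F)(F)F)c(C(=O)N/N=C/c2cccc(C(F)(F)F)c2)s1`: 8.16 ug/mL
compound 2 `CN(C(=O)NC(=O)c1ccc(F)c(F)c1)c1nc(C(F)(F)F)c(C(=O)N/N=C/c2ccc(C(F)(F)F)cc2)s1`: 6.07 ug/mL
compound 3 `CN(C(=O)NC(=O)c1ccc(C(F)(F)F)cc1)c1nc(C(F)(F)F)c(C(=O)N/N=C/c2ccc(C(F)(F)F)cc2)s1`: > 100 ug/mL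

Compound 3 gives only a limit in this assay, namely > 100 ug/mL, which is the limit of > 100 ug/mL in this assay, at which 1 of the 3 values shown sits. Compound 4 `CN(C(=O)NC(=O)c1cccc(C(F)(F)F)c1)c1nc(C(F)(F)F)c(C(=O)N/N=C/c2ccc(C(F)(F)F)cc2)s1` differs from compound 3 by 3-(trifluoromethyl)phenyl in place of 4-(trifluoromethyl)phenyl on a carbonyl carbon. Going by the values given here, the one measured step touching the same carbonyl carbon is an at least 16-fold higher number from compound 2 to compound 3 (1.21 log units; beyond the scatter), a large loss on arrival of the 4-(trifluoromethyl)phenyl group. Compound 1, which carries the 3-(trifluoromethyl)phenyl group but a different hydrazone ring, gives 8.16 ug/mL in this assay. Since compound 3 stands only at a limit, the step to compound 4 can only be bounded; compound 4 is expected to return to a measurable value, with an at least 8.3-fold lower number from compound 3 to compound 4 (0.92 log units; beyond the scatter), and the estimate for compound 4 is 12 ug/mL, ranging from 4 ug/mL to 60 ug/mL.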

Compound 4, half-maximal inhibitory concentration: 6.2 ug/mL
For compound 4 the middle estimate is 1.9-fold (0.29 log units) above the measured one, and the stated range covers the measured number.
By their numbers in this assay, from the lowest: compounds 2, 4 and 1 (each within the scatter of the next). At a limit, above all of these: compound 3.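

In this assay the 3-(trifluoromethyl)phenyl group on the carbonyl carbon gives an at least 16-fold lower number from compound 3 to compound 4 (1.20 log units; beyond the scatter), so the loss at this position follows where the trifluoromethyl sits on the ring, not its presence. This group and 3,4-difluorophenyl are not told apart, with a 1.0-fold higher number from compound 2 to compound 4 (0.01 log units; within the scatter), and the same change on the carbon with a double bond to nitrogen gives a 1.3-fold lower number from compound 1 to compound 4 (0.12 log units; within the scatter), so that site accepts either ring with this acyl group. The value of compound 3 is a limit: the limit of > 100 ug/mL in this assay, at which 1 of the 4 values shown sits.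

Going by these compounds, whether 4-(trifluoromethyl)phenyl on the carbonyl carbon costs as much when 3-(trifluoromethyl)phenyl sits on the carbon with a double bond to nitrogen stays open. Also open, on these data alone, is how an amine or a carboxylic acid on the acyl ring would read.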